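This account rests on a few compounds, and the source may have more. Where it says the series, first, only, none or still open, it means among the compounds named here.

In a functional assay on BXPC-3 cells (Homo sapiens) for antiproliferative activity, read by sulforhodamine B assay, with a stated time of 72 h (on this read-out lower numbers stand for stronger inhibition and higher numbers for weaker inhibition), compound 1 `C=CCOC(=O)C1=C2C(=NC1=O)c1cccc3cccc2c13` gives 4800 nM, compound 2 `CCCSC(=O)COC(=O)C1=C2C(=NC1=O)c1cccc3cccc2c13` gives 10100 nM, and compound 3 `C=CCSc1ccc2c3c(cccc13)C1=NC(=O)C(C(=O)OCC(=O)SCCC)=C12` gives 13700 nM. Compound 4 `C=CCOC(=O)C1=C2C(=NC1=O)c1cccc3c(SCC=C)ccc2c13` has not been measured in this assay.

The cores of compound 2 and compound 3 differ by allylsulfanyl in place of hydrogen on an aromatic carbon, and this gives a 1.4-fold higher number from compound 2 to compound 3 (0.13 log units; within the scatter).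

Compound 1 differs from compound 2 by vinyl in place of (propylsulfanyl)carbonyl on a saturated chain carbon bound to an oxygen next to a carbonyl group, with a step of a 2.1-fold lower number from compound 2 to compound 1 (0.32 log units; beyond the scatter). Compound 4 differs from compound 3 by vinyl in place of (propylsulfanyl)carbonyl on a saturated chain carbon bound to an oxygen next to a carbonyl group. The wording of the place is identical in both cases, so this is the same change made twice within the set, once measured and once not.

For compound 4 the expected step is a 2.1-fold lower number from compound 3 to compound 4 (0.32 log units; beyond the scatter), matching a 2.1-fold lower number from compound 2 to compound 1 (0.32 log units; beyond the scatter). This rests on a single measured instance of the change, and the two cores are taken as comparable settings because a 1.4-fold higher number from compound 2 to compound 3 (0.13 log units; within the scatter) sits within the usual scatter. Compound 4 is thus estimated at 6500 nM in this assay, with the expected range running from 3500 nM to 12000 nM.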

Compound 4, half-maximal inhibitory concentration: 2500 nM
Compound 4: middle estimate off by 2.6-fold (0.41 log units), on the high side; measured number outside the range, below it.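

Vinyl in place of (propylsulfanyl)carbonyl gives a 5.5-fold lower number from compound 3 to compound 4 (0.74 log units; beyond the scatter) in this assay, in the same direction as the earlier step on the core without allylsulfanyl, and the two steps do not differ beyond what scatter allows: the same change on two cores in this assay, a 2.1-fold lower number (0.32 log units; beyond the scatter) from compound 2 to compound 1 and a 5.5-fold lower number (0.74 log units; beyond the scatter) from compound 3 to compound 4, 2.6-fold (0.42 log units) apart, within the scatter of two such steps. Allylsulfanyl in place of hydrogen on an aromatic carbon gives a 1.9-fold lower number from compound 1 to compound 4 (0.28 log units; within the scatter), so neither instance of this change moves the number beyond the scatter: the same change on two cores in this assay, a 1.4-fold higher number (0.13 log units; within the scatter) from compound 2 to compound 3 and a 1.9-fold lower number (0.28 log units; within the scatter) from compound 1 to compound 4, 2.6-fold (0.42 log units) apart, within the scatter of two such steps. These four compounds support carrying both changes between these two cores, but with one pair of instances per change they do not show that the step sizes are equal or that they differ, and they say nothing about other cores.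

Going by these compounds, it remains open whether a longer chain, an amide or a carboxylic acid at the allyloxycarbonyl place would follow the same trend. On these data alone, it is also open whether an amine or a methoxy group in place of allylsulfanyl on the aromatic carbon would stay within the scatter.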